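From pyrimidin-2-yl to ethyl on a carbonyl carbon

A few compounds are considered here, and "the series" means these few. Any claim that something is new, unique, unknown or untested is made for them only; others in the source may bear on it.

In a functional assay on A2780 cells (Homo sapiens) for antiproliferative activity, read by CellTiter-Glo, with a stated time of 72 h (a higher number here means a weaker inhibitor, a lower number a stronger inhibitor), compound 3 `C[C@H](NC(=O)c1ncccn1)c1ccc(NC(=O)N2CC(c3cccnc3)C2)cc1` gives 36 nM and compound 1 `O=C(Nc1ccc(CN2C(=O)c3ccccc3C2=O)cc1)[C@H]1C[C@@H]1c1cccnc1` gives 27 nM, two values within the scatter of each other. Compound 2 `O=C(Nc1ccc(CN2Cc3ccccc3C2=O)cc1)N1CCC(c2cccnc2)C1` gives > 2500 nM; 1030 nM (2 entries). Compound 4 `CCC(=O)N[C@@H](C)c1ccc(NC(=O)N2CC(c3cccnc3)C2)cc1`, still unmeasured, carries ethyl in place of pyrimidin-2-yl on a carbonyl carbon. Among the compounds with values here, no measured pair isolates this change, so any forecast in this assay remains tentative. Only a slight move towards a higher number, not beyond the scatter, is expected for a 1.4-fold higher number from compound 3 to compound 4 (0.14 log units; within the scatter). The estimate for compound 4 is 50 nM, with an expected range of 15 nM to 200 nM.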

Compound 4, half-maximal inhibitory concentration: 25 nM
The estimate for compound 4 lay 2.0-fold (0.30 log units) above the measured number; measured number inside the range.
By their numbers in this assay, from the lowest: compounds 4, 1 and 3 (each within the scatter of the next).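

In this assay the change to this position gives a 1.4-fold lower number from compound 3 to compound 4 (0.16 log units; within the scatter). Within the data shown here, this is the first direct comparison at this carbonyl carbon, and it shows that the pyrimidin-2-yl ring, with its hydrogen-bond acceptors, can be replaced by the much smaller ethyl without a change beyond the scatter. The data shown offer no explanation for this tolerance.

A single pair cannot show how far this tolerance extends. From the compounds shown here alone, whether a longer chain, an amine or a carboxylic acid would fit here as well remains open.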